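Moving the chlorine around the phenyl ring of a pyrazoline sulfonamide

A few compounds are considered here, and "the series" means these few. Any claim that something is new, unique, unknown or untested is made for them only; others in the source may bear on it.

The three measured compounds share one core and differ only in the phenyl group on the saturated ring carbon. Compound 1 `Cc1cc(O)c(C2=NN(c3ccc(S(N)(=O)=O)cc3)C(c3ccccc3)C2)cc1Cl` carries a plain phenyl and gives 47.4% in a functional assay on the whole organism (strain Wistar) for inhibition, with Rattus norvegicus as the target, read by paw edema, with stated times of 30 min and 3 h, at a dose of 20 mg/kg by the oral route; a lower number here means less inhibition, a higher number more inhibition at the dose given (going by the name of the read-out). Compound 2 `Cc1cc(O)c(C2=NN(c3ccc(S(N)(=O)=O)cc3)C(c3ccccc3O)C2)cc1Cl` gives 73.6%, the step of a number 26.2 percentage points higher from compound 1 to compound 2 (beyond the scatter) coming from a hydroxy in place of hydrogen on an aromatic carbon. Compound 3 `Cc1cc(O)c(C2=NN(c3ccc(S(N)(=O)=O)cc3)C(c3ccccc3Cl)C2)cc1Cl` gives 55.3% and stands second highest of the three: its step of a number 18.3 percentage points lower from compound 2 to compound 3 (beyond the scatter) sets it clearly apart from compound 2, while the step of a number 7.9 percentage points higher from compound 1 to compound 3 (within the scatter) leaves it indistinguishable from compound 1.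

Compound 4 `Cc1cc(O)c(C2=NN(c3ccc(S(N)(=O)=O)cc3)C(c3ccc(Cl)cc3)C2)cc1Cl` keeps the same atoms as compound 3 but joins them differently: 4-chlorophenyl in place of 2-chlorophenyl on a saturated ring carbon. For the measured compounds named here, no measured step moves a group from one aromatic carbon to another; the only step that touches chlorine at all, a number 7.9 percentage points higher from compound 1 to compound 3 (within the scatter), is itself within the scatter, so a chlorine at that ring has so far made little difference. With nothing in the data pointing either way, the step of a number 0.3 percentage points lower from compound 3 to compound 4 (within the scatter) is expected to stay within the scatter. Compound 4 is therefore estimated at 55%, in a range from 40% to 70%.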

Compound 4, a percentage reported as inhibition, in the whole organism at one dose (the size of the read-out at that dose, not a potency): 65.8%
Compound 4: middle estimate off by 10.8 percentage points, on the low side, and the stated range covers the measured number.
By their numbers in this assay, from the lowest: compounds 1 and 3 (each within the scatter of the next); then compounds 4 and 2 (each within the scatter of the next).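

For the compounds shown here, the chlorine's place on this phenyl ring counts in this assay: the step of a number 10.5 percentage points higher from compound 3 to compound 4 (beyond the scatter) is the first measured change that moves a group around the ring without changing its atoms, and the step of a number 18.4 percentage points higher from compound 1 to compound 4 (beyond the scatter) shows that a chlorine on this ring can matter, which the 2-chlorophenyl of the earlier compounds did not show. The 4-chlorophenyl also reaches the level set by the 2-hydroxyphenyl, as the step of a number 7.8 percentage points lower from compound 2 to compound 4 (within the scatter) leaves the two unresolved, so a hydroxy group is not the only substituent on this ring that gives a number of that size. Nothing in the data accounts for the difference between the two chlorine positions.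

Going by these compounds alone, whether the effect of position holds for other groups stays open, as the chlorine is the only group seen at two places on this ring. It is also unknown how an amine, a methoxy group or a carboxylic acid in place of that chlorine would read in this assay, which reports a single oral dose and so gives no potency.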